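Replacing 4-fluorophenyl with 3-formylphenyl on the shared core

A few compounds are considered here, and "the series" means these few. Any claim that something is new, unique, unknown or untested is made for them only; others in the source may bear on it.

In a functional assay on COLO 205 cells (Homo sapiens) for inhibition, read by MTT assay, with a stated time of 48 h (on this read-out lower numbers stand for stronger inhibition and higher numbers for weaker inhibition), compound 1 (`COc1cc(C(=O)/C=C/c2cc(O)ccc2O)cc(OC)c1OC`) gives > 100000 nM, which is a limit and not a number. Within the data shown here, compound 2 (`COc1cc(C(=O)/C=C/c2ccc(F)cc2)cc(OC)c1OC`) gives 25700 nM, the only actual number so far. Compound 3 (`COc1cc(C(=O)/C=C/c2cccc(C=O)c2)cc(OC)c1OC`) differs from compound 2 as follows: 3-formylphenyl in place of 4-fluorophenyl on a double-bonded chain carbon bound to a double-bonded chain carbon. Among the measured compounds shown here, the one measured step is an at least 3.8-fold lower number from compound 1 to compound 2 (0.59 log units; beyond the scatter), which rests on the limit of > 100000 nM in this assay, at which 1 of the 2 values shown sits, and does not involve 3-formylphenyl, so it offers little guide to size or direction. What is expected is a 1.2-fold higher number from compound 2 to compound 3 (0.07 log units; within the scatter), a change not clearly beyond the scatter in this assay. For compound 3 the estimated value is 30000 nM, with an expected range of 10000 nM to 90000 nM.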

Compound 3, half-maximal inhibitory concentration: 22500 nM
Estimate against measurement, compound 3: 1.3-fold (0.12 log units) above, within the range that was stated.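

Setting 3-formylphenyl in place of 4-fluorophenyl gives a 1.1-fold lower number from compound 2 to compound 3 (0.06 log units; within the scatter), so in this assay this place on the chain takes a ring with a hydrogen-bond acceptor and no fluorine without a readable difference. A second ring also stands clear of the 2,5-dihydroxyphenyl compound, with an at least 4.4-fold lower number from compound 1 to compound 3 (0.64 log units; beyond the scatter), though this step has only one firm end: the limit of > 100000 nM in this assay, at which 1 of the 3 values shown sits. The compounds shown leave open whether a ring carrying an amine or a carboxylic acid at this place would stay level with compound 2 and compound 3.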